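A few compounds are considered here, and "the series" means these few. Any claim that something is new, unique, unknown or untested is made for them only; others in the source may bear on it.

Measured so far in this series:
compound 1, `Clc1ccc(Cn2cc(COc3ccc(Cl)cc3)nn2)cc1`: 17.4 ug/mL
compound 2, `Clc1ccc(OCc2cn(Cc3ccc(Br)cc3)nn2)cc1`: 52.9 ug/mL
compound 3, `Clc1ccc(Cn2cc(COc3c(Cl)cc(Cl)cc3Cl)nn2)cc1`: 25.1 ug/mL

All three were run in an ADME assay on THP-1 cells (Homo sapiens) for inhibition, read by MTT assay, with a stated time of 48 h; on this read-out higher numbers stand for weaker inhibition of growth and lower numbers for stronger inhibition of growth. Compound 2 differs from compound 1 by bromo in place of chloro on an aromatic carbon, and this gave a 3.0-fold higher number from compound 1 to compound 2 (0.48 log units; beyond the scatter). Compound 3 shares the structural theme but the difference between the core of compound 1 and the core of compound 3 is not broken down here; its value sits near that of compound 1 and within the usual scatter of it. Compound 4, `Clc1cc(Cl)c(OCc2cn(Cc3ccc(Br)cc3)nn2)c(Cl)c1`, is not yet measured and differs from compound 3 by bromo in place of chloro on an aromatic carbon, the same change as from compound 1 to compound 2. In this assay, within the data shown here, a step of about the same size is expected, a 2.8-fold higher number from compound 3 to compound 4 (0.45 log units; beyond the scatter), resting on the single measured pair, because a 3.0-fold higher number from compound 1 to compound 2 (0.48 log units; beyond the scatter) is the only guide. Compound 4 is thus estimated at 70 ug/mL, with a range from 35 ug/mL to 140 ug/mL.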

Compound 4, concentration for 50% growth inhibition: 58.7 ug/mL
For compound 4 the middle estimate is 1.2-fold (0.08 log units) above the measured one; the range from low to high includes it.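

In this assay, 4-bromobenzyl in place of 4-chlorobenzyl gives a 2.3-fold higher number from compound 3 to compound 4 (0.37 log units; beyond the scatter), in the same direction as on the core of compound 1 and with no size difference that can be told apart: the same change on two cores in this assay, a 3.0-fold higher number (0.48 log units; beyond the scatter) from compound 1 to compound 2 and a 2.3-fold higher number (0.37 log units; beyond the scatter) from compound 3 to compound 4, 1.3-fold (0.11 log units) apart, within the scatter of two such steps
On these two cores, then, the change carries over as weaker inhibition of growth, and a step read on one core is a fair guide to the other. Two pairs say nothing about other cores or about what underlies the step.

Open, on these data alone, is whether the trend extends from chloro and bromo to iodo or fluoro in the same place. Also open, as far as these compounds go, is what an amine or a carboxylic acid would do there.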